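Removing the methoxy group: what to expect for cytotoxicity

The source may report more compounds than this note shows. Statements on the series, on what has been measured and on what is new or still open speak of the compounds shown alone.

Compound 1 `COc1ccc(C(=O)CSc2nc(Cc3cc(C)cc(C)c3)c(C)c(=O)[nH]2)cc1` gives in an ADME assay on MT4 cells (Homo sapiens) for cytotoxicity (on this read-out higher numbers stand for lower toxicity in this test and lower numbers for higher toxicity in this test), a limit of the assay, > 308000 nM.
Compound 2 `CCc1c(Cc2cccc(Br)c2)nc(SCC(=O)c2ccc(OC)cc2)[nH]c1=O` gives in this assay 142000 nM.
Compound 3 `CCc1c(Cc2cc(C)cc(C)c2)nc(SCC(=O)c2ccc(OC)cc2)[nH]c1=O` gives in this assay a limit of the assay, >= 239000 nM.

Compound 3 therefore stands at a limit rather than a number, as does compound 1; only compound 2 has a plain number among the three. Going an at least 1.6-fold higher number from compound 2 to compound 3 (0.22 log units; that floor lies within the scatter) is the one readable step. Going a step that the two limits leave unreadable from compound 1 to compound 3 gives no readable size. Both of these steps alter the group on the saturated chain carbon bound to an aromatic carbon and leave the rest of the molecule untouched.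

Compound 4 `CCc1c(Cc2cc(C)cc(C)c2)nc(SCC(=O)c2ccccc2)[nH]c1=O` differs from compound 3 in one place: hydrogen in place of methoxy on an aromatic carbon. Among the measured compounds shown here, none of the measured steps changes this part of the molecule, so they offer no basis for expecting a shift beyond the scatter in this assay in either direction. The estimate for compound 4 is accordingly 220000 nM, with a range from 80000 nM to 400000 nM. That corresponds to an expected step of an at least 1.0-fold lower number from compound 3 to compound 4 (0.03 log units; that floor lies within the scatter), and the measured value will show whether the methoxy group mattered.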

Compound 4, half-maximal cytotoxic concentration: > 318000 nM
Compound 4 ended at the assay's limit; the forecaster's own chance of this, stated with the estimate: 50%; middle value at least 1.4-fold (0.16 log units) away from the limit.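

Compound 3 and compound 4 both stand at a limit of this assay rather than at a plain number, so the step between them cannot be read. Whether swapping methoxy for hydrogen changes this read-out at all stays open among the compounds shown.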